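From trifluoromethoxy to methoxy on the shared core

A few compounds are considered here, and "the series" means these few. Any claim that something is new, unique, unknown or untested is made for them only; others in the source may bear on it.

Measured in a functional assay on Bel-7402 cells (Homo sapiens) for inhibition, read by MTT assay, with a stated time of 24 h, tested at 100 ug/mL; a higher number here means more inhibition of growth at the concentration tested, a lower number less inhibition of growth:
- compound 1 `O=C(CCCCC(S)CCS)Nc1ccc(F)cc1`: 11.7%
- compound 2 `O=C(CCCCC(S)CCS)Nc1ccc(OC(F)(F)F)cc1`: 49.7%

Of these two numbers, compound 2 holds the higher, at 49.7%. Next in line is compound 3 `COc1ccc(NC(=O)CCCCC(S)CCS)cc1`, not yet measured. Its structure departs from compound 2 by one change: methyl in place of trifluoromethyl on an oxygen on an aromatic ring. In words, this is methyl in place of trifluoromethyl on an oxygen on an aromatic ring, or trifluoromethoxy to methoxy.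

Among the compounds with values here, no measured step covers this exact change. Within the data shown here, the only step available is a number 38 percentage points higher from compound 1 to compound 2 (beyond the scatter), with trifluoromethoxy in place of fluoro on an aromatic carbon, a large move beyond the scatter. That single step shows the group on this aromatic carbon can matter a great deal, but it cannot say how methoxy will rank. Removing the trifluoromethoxy group is expected to give back part of that gain, so a downward move beyond the scatter is expected. The estimated step is a number 22.7 percentage points lower from compound 2 to compound 3 (beyond the scatter). For compound 3 the expected value is 27%, with an estimated range of 10% to 45%.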

Compound 3, percent growth inhibition at one concentration: 22.5%
The estimate for compound 3 lay 4.5 percentage points above the measured number; measured number inside the range.
By their numbers in this assay, from the lowest: compound 1; then compound 3; then compound 2.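

In this assay, the oxygen on the aromatic ring stays in place while trifluoromethyl gives way to methyl, and the result is a number 27.2 percentage points lower from compound 2 to compound 3 (beyond the scatter); the oxygen alone therefore does not keep the level of compound 2, and the group carried on it counts. Methoxy does not fall all the way back to the fluoro level either, with a number 10.8 percentage points higher from compound 1 to compound 3 (beyond the scatter), so across these three compounds this aromatic carbon gives three separate levels, rising from fluoro through methoxy to trifluoromethoxy, with every step beyond the scatter. Nothing measured here accounts for this order.

Still open, going by these compounds, is whether trifluoromethyl set directly on the aromatic carbon, with no oxygen, would stand nearer to compound 2 or to compound 3, and whether the three fluorines or the size of the group on the oxygen set the level, which an ethoxy or a difluoromethoxy group would help to separate. Also open, on these data alone, is where an amine or a carboxylic acid on this aromatic carbon would fall, and whether the same order holds at other concentrations.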